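This account rests on a few compounds, and the source may have more. Where it says the series, first, only, none or still open, it means among the compounds named here.

Values measured in a functional assay on P388 cells (Mus musculus) for inhibition; on this read-out lower numbers stand for stronger inhibition and higher numbers for weaker inhibition:
- Compound 1 `Cc1ccc(/C=C2\CCc3ccccc3C2=O)cc1` gives 17700 nM
- Compound 2 `O=C1/C(=C/c2ccc(Cl)cc2)CCCc2ccccc21` gives 9500 nM
- Compound 3 `O=C1/C(=C/c2ccc(Br)cc2)CCCc2ccccc21` gives 18600 nM

Compound 3 stands within the scatter of both other compounds, so the three values cannot be ranked. The next compound, compound 4 `CN(C)c1ccc(/C=C2\CCCc3ccccc3C2=O)cc1`, carries dimethylamino in place of bromo on an aromatic carbon, para to a large group: dimethylamino in place of bromo on an aromatic carbon.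

Among the compounds with values here, only one measured step bears on this position, a 2.0-fold higher number from compound 2 to compound 3 (0.29 log units; within the scatter), where bromo replaces chloro, and it lies within the scatter. Within the data shown here, that step compares two halogens, and no measured compound carries dimethylamino, so the data give no direction for the new group. No step beyond the scatter is therefore expected in this assay, though the uncertainty is wide. The expected change is a 1.6-fold lower number from compound 3 to compound 4 (0.19 log units; within the scatter). For compound 4 the estimated value is 12000 nM, with an expected range from 3500 nM to 40000 nM.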

Compound 4, half-maximal inhibitory concentration: 1900 nM
The estimate for compound 4 lay 6.3-fold (0.80 log units) above the measured number; measured number below the stated range.
By their numbers in this assay, from the lowest: compound 4; then compounds 2, 1 and 3 (each within the scatter of the next).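

On the aromatic carbon para to a large group, this assay gives a 9.8-fold lower number from compound 3 to compound 4 (0.99 log units; beyond the scatter) when dimethylamino replaces bromo, and a 5.0-fold lower number from compound 2 to compound 4 (0.70 log units; beyond the scatter) when dimethylamino replaces chloro; both steps lie beyond the scatter. The earlier exchange of one halogen for the other, a 2.0-fold higher number from compound 2 to compound 3 (0.29 log units; within the scatter) and within the scatter, had shown no such movement, so this position is not indifferent to the group it carries, and among these compounds only the change from halogen to dimethylamino moves the number clearly. Nothing measured here accounts for this result.

On these data alone, how an amino group, a methoxy group or a diethylamino group would behave at this position remains open. As far as these compounds go, it also remains open whether dimethylamino would give a similar step on the core of compound 1.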